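Methoxy to ethoxy on compound 3

The source may hold more compounds than are shown below. What is called first, only, known or untested is meant among the compounds shown, and "the series" means these compounds.

In a functional assay on HaCaT cells (Homo sapiens) for antiproliferative activity, read by sulforhodamine B assay, with a stated time of 3 days (a lower number here means a stronger inhibitor, a higher number a weaker inhibitor), compound 3 (`CCOc1ccc(OC)c(CCc2ccc(O)c(C(=O)OC)c2)c1`) gives 540 nM, the middle of three numbers. Compound 1 (`COC(=O)c1cc(CCc2cc(O)ccc2OC)ccc1O`) lies higher at 8700 nM, and compound 2 (`CCOc1ccc(OC)cc1CCc1ccc(O)c(C(=O)OC)c1`), with ethoxy on the oxygen that changes here, lies lower at 120 nM. Compound 4 (`CCOc1ccc(OCC)c(CCc2ccc(O)c(C(=O)OC)c2)c1`) differs from compound 3 by methyl in place of hydrogen on a saturated chain carbon bound to an oxygen on an aromatic ring, which turns methoxy into ethoxy. Going by the values given here, the one measured step bearing on this is a 16-fold lower number from compound 1 to compound 3 (1.21 log units; beyond the scatter), a large step with ethyl in place of hydrogen on an oxygen on an aromatic ring. The present change sits on a different oxygen and adds only methyl, so a smaller step towards a lower number is expected. The expected change is a 2.7-fold lower number from compound 3 to compound 4 (0.43 log units; beyond the scatter). The estimate for compound 4 is 200 nM, within 70 nM to 600 nM.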

Compound 4, half-maximal inhibitory concentration: 380 nM
Compound 4: middle estimate off by 1.9-fold (0.28 log units), on the low side; low and high end bracket the measured number.
By their numbers in this assay, from the lowest: compound 2; then compounds 4 and 3 (each within the scatter of the next); then compound 1.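

Methoxy to ethoxy on this oxygen gives a 1.4-fold lower number from compound 3 to compound 4 (0.15 log units; within the scatter), so the added methyl leaves the number unchanged within the scatter. The same methoxy to ethoxy change on the other oxygen gives a 3.2-fold higher number from compound 2 to compound 4 (0.50 log units; beyond the scatter), so among these compounds the result depends on which oxygen carries it. Nothing here accounts for that difference. Still open, from the compounds shown here alone, is how a longer chain, such as propyl, would read on either oxygen. An amine on this chain, or a carboxylic acid in place of the methyl ester, is equally unresolved.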